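Chloro for Methyl Where Every Measured Value Is a Limit

The source may report more compounds than this note shows. Statements on the series, on what has been measured and on what is new or still open speak of the compounds shown alone.

Compound 1, `Cc1ccc(S(=O)(=O)Oc2ccc3c(c2C)[C@H](Cn2cc(-c4ccc(Cl)cc4)nn2)[C@@]24CC(=O)[C@@](C)(CC[C@@H]32)C4)cc1`, gives > 20000 nM in a functional assay on MCF7 cells (Homo sapiens) for cytotoxicity, read by MTT assay, with a stated time of 4 days (a higher number here means a weaker inhibitor, a lower number a stronger inhibitor), which is a limit of the assay rather than a number.
Compound 2, `Cc1ccc(-c2cn(C[C@H]3c4c(ccc(OS(=O)(=O)c5ccc(C)cc5)c4C)[C@@H]4CC[C@@]5(C)C[C@]43CC5=O)nn2)cc1`, gives > 20000 nM in this assay, again a limit.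
Compound 3, `C=C1C[C@]23C[C@@]1(O)CC[C@H]2c1cc(Br)c(O)c(C)c1[C@@H]3Cn1cc(-c2ccc(C)cc2)nn1`, gives > 20000 nM in this assay, also a limit.

Compound 4, `C=C1C[C@]23C[C@@]1(O)CC[C@H]2c1cc(Br)c(O)c(C)c1[C@@H]3Cn1cc(-c2ccc(Cl)cc2)nn1`, has not been measured. It differs from compound 3 by chloro in place of methyl on an aromatic carbon. The same change separates compound 2 from compound 1, (chloro in place of methyl on an aromatic carbon), and there it gave a step that the two limits leave unreadable from compound 2 to compound 1. How the core of compound 3 differs from the core of compound 2 is not broken down here. For the measured compounds named here, the only evidence on the measured compounds is the limit of > 20000 nM in this assay, at which 3 of the 3 values shown sit. With both ends of the earlier step sitting at the limit, no size can be read from it, so the step is expected to be a step that the limit leaves unreadable from compound 3 to compound 4, most likely ending again at a limit. Compound 4 is therefore estimated at 30000 nM, with a range from 15000 nM to 100000 nM.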

Compound 4, half-maximal inhibitory concentration: 10200 nM
Beside the measured number, compound 4's estimate is 2.9-fold (0.47 log units) above it; measured number outside the range, below it.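

In this assay, changing 4-methylphenyl to 4-chlorophenyl gives an at least 1.9-fold lower number from compound 3 to compound 4 (0.29 log units; that floor lies within the scatter), and compound 4 reads 10200 nM. For compound 3, > 20000 nM is a limit, not a number. The true size of this step therefore stays unknown, its floor alone does not establish a real gain, and the same change on the other core cannot be read, so nothing here shows that the change carries from one core to another: the limit of > 20000 nM in this assay, at which 3 of the 4 values shown sit.

The compounds shown leave open whether another group in the same place, such as an amine or a carboxylic acid, would give a readable value on either core.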